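Carbamoylphenyl amides on the shared piperidine core

The source may report more compounds than this note shows. Statements on the series, on what has been measured and on what is new or still open speak of the compounds shown alone.

Two compounds of the series have a reading in an assay on HEK293 cells for inhibition of Voltage-dependent N-type calcium channel subunit alpha-1B (Homo sapiens), read by FLIPR and calcium flux, tested at 1 uM; a higher number here means more inhibition at the concentration tested (going by the name of the read-out), a lower number less inhibition. Compound 1 `CS(=O)(=O)c1ccc(F)cc1C(=O)N1CCC(N(C2CC2)S(=O)(=O)c2ccccc2C(F)(F)F)CC1` gives 17% in this assay. Compound 2 `NC(=O)c1ccc(C(=O)N2CCC(N(C3CC3)S(=O)(=O)c3cccc(C(F)(F)F)c3)CC2)cc1` gives 12% in this assay, and the gap between compound 2 and compound 1 lies within the scatter of repeated measurements, so the two cannot be told apart on these numbers. The two numbers are thus level in this assay.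

Compound 3 `NC(=O)c1ccccc1C(=O)N1CCC(N(C2CC2)S(=O)(=O)c2cccc(C(F)(F)F)c2)CC1` has not been measured. It differs from compound 2 in one place: 2-carbamoylphenyl in place of 4-carbamoylphenyl on a carbonyl carbon. For the measured compounds named here, no pair of measured compounds shows a step of this kind, so there is no measured precedent for the size or direction of the change. With compound 2 at 12% and compound 1 at 17%, level with each other within the scatter, the expectation for the step from compound 2 to compound 3 is none beyond the scatter, no change at the digits printed from compound 2 to compound 3 (within the scatter). Compound 3 is therefore estimated at 12% in this assay, with a range from 0% to 30%.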

Compound 3, a percentage reported as inhibition, at one concentration (the size of the read-out at that concentration, not a potency): 15%
Compound 3: middle estimate off by 3 percentage points, on the low side; the range from low to high includes it.
By their numbers in this assay, from the lowest: compounds 2, 3 and 1 (each within the scatter of the next).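

For the compounds shown here, the step from 4-carbamoylphenyl to 2-carbamoylphenyl on the carbonyl carbon is the first measured change at this position: in this assay it reads a number 3 percentage points higher from compound 2 to compound 3 (within the scatter) and so leaves the two compounds level. Between this pair, the place of the carbamoyl group on the phenyl ring therefore makes no difference that can be read in this assay. No measurement at hand bears on why the reading stays level.

Compound 1 differs from compound 2 and compound 3 in more than one place, so it adds nothing on this change alone. Still open, going by these compounds, is whether a carboxylic acid, a nitrile or an aminomethyl group in place of the carbamoyl group would give a step beyond the scatter.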